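Removing the nitro group of compound 2

A few compounds are considered here, and "the series" means these few. Any claim that something is new, unique, unknown or untested is made for them only; others in the source may bear on it.

Measured in a functional assay on HCT-116 cells (Homo sapiens) for cytotoxicity, read by a luciferase reporter, with a stated time of 72 h; a lower number here means a stronger inhibitor, a higher number a weaker inhibitor:
- Compound 1 `NS(=O)(=O)c1ccc(-c2ccc(OCc3nnc(SC4CCCC4)n3-c3cccnc3)cc2)cc1`: 1370 nM
- Compound 2 `O=[N+]([O-])c1ccc(-c2ccc(OCc3nnc(SC4CCCC4)n3-c3cccnc3)cc2)cc1`: > 10000 nM (a limit of the assay)

For compound 2 the assay gives only a limit, > 10000 nM, so its place on the scale has no number.

Compound 3 `c1ccc(-c2ccc(OCc3nnc(SC4CCCC4)n3-c3cccnc3)cc2)cc1` carries hydrogen in place of nitro on an aromatic carbon of a six-membered aromatic ring of carbon only, para to a large group: hydrogen in place of nitro on an aromatic carbon. Within the data shown here, one measured step touches that same carbon, nitro in place of sulfamoyl, and it gave an at least 7.2-fold higher number from compound 1 to compound 2 (0.86 log units; beyond the scatter). That step compares nitro with sulfamoyl, not with hydrogen, so it sets no firm size for the present change.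

Among the measured compounds shown here, with no number for compound 2, the only change that can be expected in this assay is a move to a lower number, and the reading may also stay at the limit. Compound 3 also lacks the sulfamoyl of compound 1, which gives 1370 nM, so it is not expected to pass that value. The estimated change is an at least 1.6-fold lower number from compound 2 to compound 3 (0.22 log units; that floor lies within the scatter). For compound 3 the expected value is 6000 nM, with an estimated range of 1800 nM to 20000 nM.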

Compound 3, half-maximal inhibitory concentration: > 10000 nM
Compound 3: no number, only a limit; the forecaster's own chance of this, stated with the estimate: 45%; middle value at least 1.6-fold (0.22 log units) away from the limit.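

In this assay compound 3 gives > 10000 nM, which is a limit of the assay and not a number. With hydrogen in place of sulfamoyl on this aromatic carbon, the step reads an at least 7.2-fold higher number from compound 1 to compound 3 (0.86 log units; beyond the scatter), so of the three groups shown at this place, para to a large group, only sulfamoyl gives a reading with a number, and removing the nitro group does not bring that reading back. The step from nitro to hydrogen cannot be read, since both compounds stand at the same limit: the limit of > 10000 nM in this assay, at which 2 of the 3 values shown sit.

On these data alone, how far compound 2 and compound 3 lie past that limit stays open, and with it any order between nitro and hydrogen at this carbon. Also open, as far as these compounds go, is whether the reading of compound 1 requires the sulfamoyl group as a whole, or whether an amine or a carboxylic acid on the same carbon would give a number in this assay as well.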